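The compounds below may be only part of what the source reports. "The series", "measured", "known", "first", "only" and "open" are said of these compounds alone.

Measured so far in a functional assay on HCT-116 cells (Homo sapiens) for antiproliferative activity, read by MTT assay, with a stated time of 18 h; a lower number here means a stronger inhibitor, a higher number a weaker inhibitor:
Compound 1 `Cc1cc2c(OCc3cc(-c4ccc(Cl)cc4)no3)ncnc2s1`: 6690 nM
Compound 2 `CCc1cc2c(OCc3cc(-c4ccc(OC)cc4)no3)ncnc2s1`: 112000 nM

Only these two compounds have numbers in this assay, so the series is still thin. Compound 2, at 112000 nM, has the higher of the two numbers and is therefore the weaker inhibitor, and the gap down to compound 1 lies beyond the scatter.

The next compound, compound 3 `CCc1cc2c(OCc3cc(-c4ccc(Cl)cc4)no3)ncnc2s1`, changes compound 2 in one place: chloro in place of methoxy on an aromatic carbon, turning 4-methoxyphenyl to 4-chlorophenyl (chloro in place of methoxy on an aromatic carbon). For the measured compounds named here, no measured pair shows this change on its own, so any forecast rests on indirect evidence. Compound 1 also carries a 4-chlorophenyl group and gives 6690 nM, which points to a number for compound 3 in that region rather than near that of compound 2.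

A clear fall in the number, beyond the scatter, is therefore expected, and the estimated step is a 14-fold lower number from compound 2 to compound 3 (1.15 log units; beyond the scatter). Compound 3 is expected at about 8000 nM, with an estimated range of 2500 nM to 30000 nM.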

Compound 3, half-maximal inhibitory concentration: 33300 nM
The estimate for compound 3 lay 4.2-fold (0.62 log units) below the measured number, and the stated range ends below it.
By their numbers in this assay, from the lowest: compound 1; then compound 3; then compound 2.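

Chloro in place of methoxy on an aromatic carbon now has a reading of its own in this assay and gives a 3.4-fold lower number from compound 2 to compound 3 (0.53 log units; beyond the scatter) with the rest of the structure unchanged. With the 4-chlorophenyl group held constant, methyl in place of hydrogen on a saturated chain carbon bound to an aromatic carbon gives a 5.0-fold higher number from compound 1 to compound 3 (0.70 log units; beyond the scatter) and so shows that this second place also moves the number beyond the scatter. The change from 4-methoxyphenyl to 4-chlorophenyl therefore lowers the number, yet compound 3 still stands above compound 1 at 6690 nM and both places matter among these three compounds.

Each change is seen only once, on a single background, so the compounds shown leave open whether the chloro step would hold with the smaller chain and what a fluoro, a nitrile or an amine would give at the same place on the ring. Nothing available accounts for the size of either step.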